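Thiophen-2-yl in place of furan-2-yl: working notes

This account rests on a few compounds, and the source may have more. Where it says the series, first, only, none or still open, it means among the compounds named here.

Of the compounds shown here, three have numbers so far in a functional assay on HCT-116 cells (Homo sapiens), read by MTT assay, with a stated time of 72 h; on this read-out lower numbers stand for stronger inhibition and higher numbers for weaker inhibition. Compound 1 (`COc1ncnc2c1c(-c1cc3ccccc3o1)cn2[C@@H]1O[C@H](CO)[C@@H](O)[C@H]1O`) gives 14500 nM, compound 2 (`C#Cc1cn([C@@H]2O[C@H](CO)[C@@H](O)[C@H]2O)c2ncnc(SC)c12`) gives 90 nM, and compound 3 (`CNc1ncnc2c1c(-c1ccco1)cn2[C@@H]1O[C@H](CO)[C@@H](O)[C@H]1O`) gives 440 nM. Compound 3 is thus the second highest of the three numbers, with compound 2 lower and compound 1 higher, and both gaps lie beyond the scatter.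

The next compound is compound 4 (`CNc1ncnc2c1c(-c1cccs1)cn2[C@@H]1O[C@H](CO)[C@@H](O)[C@H]1O`). It differs from compound 3 as follows: thiophen-2-yl in place of furan-2-yl on an aromatic carbon. Among the compounds with values here, no two measured compounds differ in only one place, so the series offers no direct precedent for this change, and the spread of the three numbers says little about it. With no such evidence for either direction, no step beyond the scatter is expected in this assay. The expected change is small, and the estimate is a 1.2-fold lower number from compound 3 to compound 4 (0.06 log units; within the scatter). For compound 4 the estimated value is 380 nM, with an expected range of 100 nM to 1400 nM.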

Compound 4, half-maximal inhibitory concentration: > 20000 nM
Compound 4: no number, only a limit; the forecaster's own chance of this, stated with the estimate: 3%; middle value at least 52-fold (1.72 log units) from the limit.
By their numbers in this assay, from the lowest: compound 2; then compound 3; then compound 1. At a limit, above all of these: compound 4.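

Exchanging furan-2-yl for thiophen-2-yl on this aromatic carbon, two ring bonds from the ring nitrogen, is far from neutral in this assay, with a single ring oxygen replaced by sulfur giving an at least 45-fold higher number from compound 3 to compound 4 (1.65 log units; beyond the scatter). In this assay compound 4 gives > 20000 nM, which is a limit of the assay and not a number. The step therefore marks a minimum size, and its true extent remains unknown: the limit of > 20000 nM in this assay, at which 1 of the 4 values shown sits.

This single pair does not show whether the sulfur atom alone accounts for the large step, and the data offer no cause for it. On these data alone, it also remains open whether a phenyl ring, a furan-3-yl group or an aminomethyl group on the same aromatic carbon would stay close to compound 3 or fall off as compound 4 does.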